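A few compounds are considered here, and "the series" means these few. Any claim that something is new, unique, unknown or untested is made for them only; others in the source may bear on it.

Measured in a functional assay on HT-29 cells (Homo sapiens) for cytotoxicity, read by MTT assay, with a stated time of 24 h; a lower number here means a stronger inhibitor, a higher number a weaker inhibitor:

Compound 1 `C#CCOc1ccc(Br)cc1/C=N/Cc1ccc(S(N)(=O)=O)cc1`: in this assay compound 1 gives 45700 nM
Compound 2 `C#CCOc1ccc([N+](=O)[O-])cc1/C=N/Cc1ccc(S(N)(=O)=O)cc1`: in this assay compound 2 gives 34800 nM
Compound 3 `NS(=O)(=O)c1ccc(C/N=C/c2cc(Br)ccc2OCc2cn(CCCOc3ccc4ccc(=O)oc4c3)nn2)cc1`: in this assay compound 3 gives 17700 nM

Within the data shown here, compound 1 and compound 2 share one core, and between them only one thing changes: nitro in place of bromo on an aromatic carbon. That change gave a 1.3-fold lower number from compound 1 to compound 2 (0.12 log units; within the scatter). Compound 3 carries a different core; how the two cores differ is not broken down here. Compound 3 stands at the lowest of the three numbers, within the scatter of compound 2 and beyond it from compound 1.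

Compound 4 `NS(=O)(=O)c1ccc(C/N=C/c2cc([N+](=O)[O-])ccc2OCc2cn(CCCOc3ccc4ccc(=O)oc4c3)nn2)cc1` is not yet measured. It differs from compound 3 by nitro in place of bromo on an aromatic carbon. This is the same kind of change as that from compound 1 to compound 2, though not the same: in compound 1 the place is para to a propargyloxy group, in compound 3 it is para to a large group. Because a 1.3-fold lower number from compound 1 to compound 2 (0.12 log units; within the scatter) stayed within the scatter, compound 4 is expected to show a 1.3-fold lower number from compound 3 to compound 4 (0.10 log units; within the scatter) in this assay. The estimate for compound 4 is 14000 nM, with a likely range from 7000 nM to 28000 nM.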

Compound 4, half-maximal inhibitory concentration: 117000 nM
The estimate for compound 4 lay 8.4-fold (0.92 log units) below the measured number; measured number outside the range, above it.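

In this assay nitro in place of bromo gave a 6.6-fold higher number from compound 3 to compound 4 (0.82 log units; beyond the scatter) and so did not repeat the step seen on the core of compound 1, which stayed within the scatter. The two steps differ by more than the scatter of two such steps allows, so in this series the size of this change cannot be carried from one core to the other: the same change on two cores in this assay, a 1.3-fold lower number (0.12 log units; within the scatter) from compound 1 to compound 2 and a 6.6-fold higher number (0.82 log units; beyond the scatter) from compound 3 to compound 4, 8.7-fold (0.94 log units) apart, beyond the scatter of two such steps. Among these compounds, this rests on only two pairs of compounds, so it shows that the core matters but not which part of the core of compound 3 is responsible, nor why, and it offers no rule for any third core.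

The compounds shown leave open whether a chloro group or an amine at the same place would follow the bromo and nitro pair on either core. They also leave open whether a longer chain in the large group of compound 3 and compound 4 would keep this gap between bromo and nitro.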